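Fluorine pattern on the phenyl ring of a pyridazinone insecticide

The source may hold more compounds than are shown below. What is called first, only, known or untested is meant among the compounds shown, and "the series" means these compounds.

Compounds measured in a functional assay on the whole organism for inhibition, with Mythimna separata as the target, with a stated time of 5 days; on this read-out higher numbers stand for an effect only at larger amounts of compound and lower numbers for an effect already at smaller amounts:
compound 1, `CC(C)(C)n1ncc(OCc2nnc(-c3ccccc3Cl)o2)c(Cl)c1=O`, gives 61.2 ug/mL;
compound 3, `CC(C)(C)n1ncc(OCc2nnc(-c3cccc(F)c3)o2)c(Cl)c1=O`, gives 7.1 ug/mL.
Compound 2, `COc1c(F)c(F)cc(-c2nnc(COc3cnn(C(C)(C)C)c(=O)c3Cl)o2)c1F`, reaches only a limit of the assay, > 300 ug/mL.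

Compound 3 stands at the lowest number among the measured compounds. The step of an 8.6-fold lower number from compound 1 to compound 3 (0.94 log units; beyond the scatter) shows that the choice of halogen and its position on the phenyl ring shifts the result clearly. Compound 4, `CC(C)(C)n1ncc(OCc2nnc(-c3cc(F)c(F)cc3F)o2)c(Cl)c1=O`, differs from compound 3 by 2,4,5-trifluorophenyl in place of 3-fluorophenyl on an aromatic carbon. Within the data shown here, no measured step covers this exact change; the nearest hints are the step from compound 1 to compound 3 and the limit of > 300 ug/mL in this assay, at which 1 of the 3 values shown sits, seen for compound 2, whose more heavily fluorinated phenyl gave no number at all. Compound 4 is therefore expected to fall at 40 ug/mL, between 10 ug/mL and 200 ug/mL. This estimate corresponds to an expected step of a 5.6-fold higher number from compound 3 to compound 4 (0.75 log units; beyond the scatter).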

Compound 4, half-maximal effective concentration: 75.7 ug/mL
Compound 4: the middle estimate sits 1.9-fold (0.28 log units) below what was measured; the measured number falls inside the stated range.
By their numbers in this assay, from the lowest: compound 3; then compounds 1 and 4 (each within the scatter of the next). At a limit, above all of these: compound 2.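

Moving to the 2,4,5-trifluorophenyl group gives an 11-fold higher number from compound 3 to compound 4 (1.03 log units; beyond the scatter), so more fluorine on this phenyl ring did not bring a lower number here. Hydrogen in place of methoxy gives an at least 3.9-fold lower number from compound 2 to compound 4 (0.59 log units; beyond the scatter), a step read from a limit of the assay for compound 2, not from a true number. The 2,4,5-trifluorophenyl and 2-chlorophenyl groups cannot be told apart: a 1.2-fold higher number from compound 1 to compound 4 (0.09 log units; within the scatter).

Going by these compounds, whether the number of fluorines or their placement on the ring matters more remains open. So does what an amine or a carboxylic acid on this phenyl ring would do.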